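Removing the Methyl from Compound 1: What to Expect

This account rests on a few compounds, and the source may have more. Where it says the series, first, only, none or still open, it means among the compounds named here.

Measured compounds:
- Compound 1 `Cc1ccc2nc(Nc3nc4ccccc4s3)sc2c1` gives 48400 nM in a functional assay on U-937 cells (Homo sapiens) for cytotoxicity, read by MTT assay, with a stated time of 48 h; on this read-out lower numbers stand for stronger inhibition and higher numbers for weaker inhibition.
- Compound 2 `Cc1ccc2nc(Nc3nc4ccc(F)cc4s3)sc2c1` gives > 50000 nM in this assay, which is a limit of the assay, not a number.
- Compound 3 `Fc1ccc2nc(NC(=S)Nc3ccc(Cl)cc3)sc2c1` gives 18700 nM in this assay.

Among the two compounds with a number, compound 1 has the higher one, meaning weaker inhibition; compound 3 gives a lower number, and that gap lies beyond the usual scatter. From the compounds shown here alone, for compound 2 the assay reports only a limit, so its number is unknown (the limit of > 50000 nM in this assay, at which 1 of the 3 values shown sits).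

Compound 4 `c1ccc2sc(Nc3nc4ccccc4s3)nc2c1` differs from compound 1 by hydrogen in place of methyl on an aromatic carbon; the core is otherwise unchanged. Among the measured compounds shown here, only one measured step stays on this core: an at least 1.0-fold higher number from compound 1 to compound 2 (0.01 log units; that floor lies within the scatter), a change of a different kind and of a size within the scatter. For the measured compounds named here, no measured step removes a methyl, so there is no direct guide to the size of this change in this assay.

On this basis the step in this assay for compound 4 is expected to be small, in no particular direction, and within the scatter. The estimate for compound 4 is 50000 nM, with a range from 25000 nM to 100000 nM. The expected step is therefore a 1.0-fold higher number from compound 1 to compound 4 (0.01 log units; within the scatter), with a real chance that the assay again reports only a limit.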

Compound 4, half-maximal inhibitory concentration: 40000 nM
Compound 4: the middle estimate sits 1.3-fold (0.10 log units) above what was measured; the range from low to high includes it.
By their numbers in this assay, from the lowest: compound 3; then compounds 4 and 1 (each within the scatter of the next). At a limit, above all of these: compound 2.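

Replacing the methyl with hydrogen gives a 1.2-fold lower number from compound 1 to compound 4 (0.08 log units; within the scatter), so in this assay the loss of this one carbon on the aromatic ring cannot be told apart from the usual scatter. Among the compounds shown here, this is the first measured step at this place on the shared core, and it shows that the methyl is not needed for the modest activity of compound 1 in this assay. The only earlier step on this core, fluoro in place of hydrogen, lay at a different place and could give no firm size, since compound 2 gives only a limit: the limit of > 50000 nM in this assay, at which 1 of the 4 values shown sits.

With only methyl and hydrogen seen at this place, the compounds shown leave open whether a different group there, such as an amine, a carboxylic acid or a longer chain, would move the number beyond the scatter in either direction. They also leave open whether hydrogen in place of methyl would stay as small a change on a core carrying other groups, or in a different assay.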